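The source may report more compounds than this note shows. Statements on the series, on what has been measured and on what is new or still open speak of the compounds shown alone.

Measured so far:
Compound 1, `Cc1nc2c(Br)c(Br)c(Br)c(Br)c2n1CC#N`, gives 14% in a functional assay on CCRF-CEM cells (Homo sapiens) for cytotoxicity, read by MTT assay, with a stated time of 24 h, tested at 20 uM; a higher number here means a weaker effect of the compound at the concentration tested, a lower number a stronger effect.
Compound 2, `N#CCCn1cnc2c(Br)c(Br)c(Br)c(Br)c21`, gives 44% in this assay.

Of the two numbers, compound 1 stands lowest; the nearest is compound 2, whose number lies higher by an amount beyond the scatter. Within the data shown here, compound 2 differs from compound 1 in more than one place, so no single step can be read from their two values; they show only that the two measured compounds sit apart, with compound 1 the stronger of the pair at the concentration tested.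

Compound 3, `Cc1nc2c(Br)c(Br)c(Br)c(Br)c2n1CCCC#N`, has not yet been measured in this assay. It keeps the shared core and the methyl of compound 1 and alters the chain on the aromatic nitrogen: 2-cyanoethyl in place of cyano on a saturated chain carbon bound to an aromatic nitrogen.

Among the measured compounds shown here, no measured pair isolates this change. For the measured compounds named here, the only hint is that compound 2, which carries a longer chain and lacks the methyl, gives 44%. Going by the values given here, on that thin basis a moderate weakening is expected for compound 3 rather than no step, with wide uncertainty. The number expected for compound 3 is 32%, within 12% to 60%. This corresponds to an expected a number 18 percentage points higher from compound 1 to compound 3 (beyond the scatter).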

Compound 3, a percentage reported as activity, at one concentration (the size of the read-out at that concentration, not a potency): 44%
Compound 3: the middle estimate sits 12 percentage points below what was measured, within the range that was stated.
By their numbers in this assay, from the lowest: compound 1; then compounds 2 and 3 (each within the scatter of the next).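

Among these compounds, the step from cyanomethyl to 3-cyanopropyl on the aromatic nitrogen is the first change in this set that can be read on its own: with the shared core and the methyl held fixed, this assay gives a number 30 percentage points higher from compound 1 to compound 3 (beyond the scatter). It shows that the chain at this position is not silent, since the longer 3-cyanopropyl chain goes with a weaker effect at the concentration tested, and the earlier pair could not show this because its two compounds differ in more than one place. Even so, this is a single step, and it gives the direction for these two chains only, not a trend with chain length. No measurement shown bears on why the number moves with this change.

The compounds shown leave open how a chain of another length would read with the methyl kept, and what the methyl itself contributes, as no pair isolates it. They also leave open whether the nitrile matters at the end of the chain, for instance whether an amine or a carboxylic acid in its place would hold or lose the effect seen with compound 1.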